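Cinnamoyl for Trifluoromethylbenzoyl on a Triazolyl Core

The source may report more compounds than this note shows. Statements on the series, on what has been measured and on what is new or still open speak of the compounds shown alone.

Measured compounds:
compound 1 `CN1CCN(c2ccc(C3=NN(C(=O)c4ccc(C(F)(F)F)cc4)C(c4ccc(N(C)C)cc4)C3)cc2)CC1` gives 84.1%
compound 2 `CN1CCN(c2ccc(C3=NN(C(=O)/C=C/c4ccccc4)C(c4ccc(N(C)C)cc4)C3)cc2)CC1` gives 71%
compound 3 `CN(C)c1ccc(C2CC(c3ccc(-n4cncn4)cc3)=NN2C(=O)c2ccc(C(F)(F)F)cc2)cc1` gives 7%

All three were tested in a functional assay on HCC1806 cells (Homo sapiens) for inhibition, read by sulforhodamine B assay, tested at 10 uM; a lower number here means less inhibition, a higher number more inhibition at the concentration tested (going by the name of the read-out). Compound 1 shows the highest of the three numbers. Moving to compound 2 by the change 2-phenylethenyl in place of 4-(trifluoromethyl)phenyl on a carbonyl carbon gives a number 13.1 percentage points lower from compound 1 to compound 2 (beyond the scatter). Compound 3 differs from compound 1 in the core, by 1H-1,2,4-triazol-1-yl in place of 4-methylpiperazin-1-yl on an aromatic carbon, and this gives a number 77.1 percentage points lower from compound 1 to compound 3 (beyond the scatter), leaving compound 3 with the lowest number of the three.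

Compound 4 `CN(C)c1ccc(C2CC(c3ccc(-n4cncn4)cc3)=NN2C(=O)/C=C/c2ccccc2)cc1` has not yet been measured. It arises from compound 3 by 2-phenylethenyl in place of 4-(trifluoromethyl)phenyl on a carbonyl carbon, the same change that was made from compound 1 to compound 2, at a place described in identical words. Compound 4 is therefore expected to show a number 4 percentage points lower from compound 3 to compound 4 (within the scatter), since compound 3 starts from 7% and the earlier change gave a number 13.1 percentage points lower from compound 1 to compound 2 (beyond the scatter), leaving little room to fall. Compound 4 is estimated at 3%. For compound 4 the expected lower end is -10%. For compound 4 the expected upper end is 16%.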

Compound 4, a percentage reported as inhibition, at one concentration (the size of the read-out at that concentration, not a potency): -3.7%
Beside the measured number, compound 4's estimate is 6.7 percentage points above it; low and high end bracket the measured number.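

On the triazolyl core in this assay, 2-phenylethenyl in place of 4-(trifluoromethyl)phenyl gave a number 10.7 percentage points lower from compound 3 to compound 4 (beyond the scatter), and this step matches the one seen on the core of compound 1: the same change on two cores in this assay, a number 13.1 percentage points lower (beyond the scatter) from compound 1 to compound 2 and a number 10.7 percentage points lower (beyond the scatter) from compound 3 to compound 4, 2.4 percentage points apart, within the scatter of two such steps With the 2-phenylethenyl carbonyl group in place, 1H-1,2,4-triazol-1-yl in place of 4-methylpiperazin-1-yl gave a number 74.7 percentage points lower from compound 2 to compound 4 (beyond the scatter), which matches the step seen with the other carbonyl group: the same change on two cores in this assay, a number 77.1 percentage points lower (beyond the scatter) from compound 1 to compound 3 and a number 74.7 percentage points lower (beyond the scatter) from compound 2 to compound 4, 2.4 percentage points apart, within the scatter of two such steps The two changes thus carry over within these four compounds, but this rests on a single pair of cores and shows neither that the transfer holds on other cores nor why either step has its size.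

The compounds shown leave open what a morpholine or an open-chain amine would give in place of 4-methylpiperazin-1-yl. They also leave open whether a simple alkyl chain in place of 2-phenylethenyl would follow the same pattern.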